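Chloro on the phenoxy ring of compound 2

The source may hold more compounds than are shown below. What is called first, only, known or untested is meant among the compounds shown, and "the series" means these compounds.

Three members of the series have been run in an assay on isolated protein for inhibition of Dihydrofolate reductase (Homo sapiens), read by spectrophotometry, using NADPH, with stated times of 5 s and 6 min, tested at 5 uM; on this read-out lower numbers stand for a weaker effect and higher numbers for a stronger effect at the one concentration tested. Compound 1 `NC1=NC2(CCSCC2)N(OCCCOc2ccc(Cl)c(Cl)c2)C(N)=N1` gives 88.4% in this assay. Compound 3 `CC(C)(C)c1ccc(OCCCON2C(N)=NC(N)=NC23CCSCC3)cc1` gives 85.3%. Compound 2 `NC1=NC2(CCOCC2)N(OCCCOc2ccccc2)C(N)=N1` reaches only a limit of this assay, > 90%, so no number is known for it. Compound 2 thus stands at the limit of > 90% in this assay, at which 1 of the 3 values shown sits, and its distance from compound 1 and compound 3 cannot be read off. Those two measured numbers lie within the usual scatter of one another, so no order between them is claimed.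

The next compound, compound 4 `NC1=NC2(CCOCC2)N(OCCCOc2ccc(Cl)cc2)C(N)=N1`, differs from compound 2 in one place: chloro in place of hydrogen on an aromatic carbon, with the difference cut one bond further out reading phenoxy to 4-chlorophenoxy. Among the compounds with values here, no step between measured compounds isolates this change. Compound 1 carries chlorine on the same ring while compound 3 carries tert-butyl, and both sit near the top of the scale, so a step in this assay from compound 2 to compound 4 of no more than the scatter is expected, in either direction, with a fair chance that compound 4 also comes back as a limit.

Compound 4 is therefore expected to give about 89% in this assay, within a range from 80% to 95%, which means an expected step of a number at least 1 percentage points lower from compound 2 to compound 4 (that floor lies within the scatter).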

Compound 4, a percentage reported as inhibition, at one concentration (the size of the read-out at that concentration, not a potency): > 90%
Compound 4: no number, only a limit; the forecaster's own chance of this, stated with the estimate: 45%; middle value at least 1 percentage points away from the limit.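

Compound 4, like compound 2, comes back from this assay only as a limit, so the effect of chloro in place of hydrogen on an aromatic carbon cannot be read as a step between them: the limit of > 90% in this assay, at which 2 of the 4 values shown sit.

The compounds shown leave open whether phenoxy to 4-chlorophenoxy changes the inhibition at all, and in which direction.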